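The compounds below may be only part of what the source reports. "The series", "measured", "known", "first", "only" and "open" are said of these compounds alone.

Measured so far:
compound 1, `Nc1nc(-c2cnco2)nc2sc(Cc3ccccc3)cc12`, in a functional assay on CHO-K1 cells for antagonist activity at adenosine receptor A1 (Homo sapiens), read by a beta-galactosidase reporter and cAMP accumulation, with stated times of 15 min and 6 h (a lower number here means a stronger inhibitor, a higher number a weaker inhibitor), compound 1 gives 106 nM
compound 2, `CC(c1ccccc1)c1cc2c(N)nc(-c3cccc(C#N)c3)nc2s1`, in this assay compound 2 gives 1770 nM

Compound 1 holds the lowest number of the two; compound 2 sits a good way higher, and the gap between them is beyond the scatter. The two differ from each other in more than one place, so that pair says nothing about any single change on its own.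

Compound 3, `Nc1nc(-c2cccnc2)nc2sc(Cc3ccccc3)cc12`, is not yet measured. Compared with compound 1 it changes as follows: pyridin-3-yl in place of 1,3-oxazol-5-yl on an aromatic carbon. Among the compounds with values here, no measured pair isolates this change, so the expectation rests on compound 1 alone, with an allowance for a shift in either direction. The step of a 1.9-fold higher number from compound 1 to compound 3 (0.28 log units; within the scatter) is expected to be small, possibly within the scatter, leaning toward a weaker number. Compound 3 is estimated at 200 nM, with a range of 60 nM to 700 nM.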

Compound 3, inhibition constant: 1420 nM
Compound 3: the middle estimate sits 7.1-fold (0.85 log units) below what was measured, and the stated range ends below it.
By their numbers in this assay, from the lowest: compound 1; then compounds 3 and 2 (each within the scatter of the next).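

The replacement of 1,3-oxazol-5-yl by pyridin-3-yl gives a 13-fold higher number from compound 1 to compound 3 (1.13 log units; beyond the scatter) in this assay and so shows that this aromatic carbon, between two ring nitrogen atoms, does not accept these two aromatic rings alike. Within the data shown here, this is the first comparison that isolates a single place, but the one pair cannot separate ring size from the number and kind of hetero atoms. Nothing on hand accounts for the size of this step.

Open, as far as these compounds go, is how other groups would fare at this position, such as a phenyl ring, a thiophene ring, a furan ring or a small amine. Also open, from the compounds shown here alone, is whether the same step would hold with a different substituent elsewhere on the shared core.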